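Chain extension on the ether-linked side chain

This account rests on a few compounds, and the source may have more. Where it says the series, first, only, none or still open, it means among the compounds named here.

Measured in a functional assay on A549 cells (Homo sapiens) for cytotoxicity, read by MTT assay, with a stated time of 72 h; on this read-out higher numbers stand for weaker inhibition and lower numbers for stronger inhibition:
compound 1 `CCCOCNc1n[n+]([O-])c2cc(OC)ccc2[n+]1[O-]`: 2540 nM
compound 2 `CCCCCOCNc1n[n+]([O-])c2ccccc2[n+]1[O-]`: 2900 nM
compound 3 `CCCCCOCNc1n[n+]([O-])c2cc(OC)ccc2[n+]1[O-]`: 2510 nM

Compound 2 gives the highest of the three numbers, but its distance to compound 1 and to compound 3 lies within the scatter, so the three compounds are not separable on these data. Compound 4 `CCCCCCCOCNc1n[n+]([O-])c2ccccc2[n+]1[O-]` differs from compound 2 by ethyl in place of hydrogen on a saturated chain carbon, five bonds along the chain from an oxygen on a saturated carbon.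

Among the compounds with values here, one measured step bears directly on this change: from compound 1 to compound 3 the chain was lengthened by the same group at a position nearer the oxygen, and in this assay that gave a 1.0-fold lower number from compound 1 to compound 3 (0.01 log units; within the scatter). The other measured step, a 1.2-fold lower number from compound 2 to compound 3 (0.06 log units; within the scatter), concerns a different position and also stays within the scatter. Nothing in the set shows a chain extension moving the number beyond the scatter.

Compound 4 is therefore expected to come out near compound 2, with an expected step of a 1.0-fold lower number from compound 2 to compound 4 (0.02 log units; within the scatter) in this assay. The estimate for compound 4 is 2800 nM, expected between 1400 nM and 5600 nM.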

Compound 4, half-maximal inhibitory concentration: 3490 nM
For compound 4 the middle estimate is 1.2-fold (0.10 log units) below the measured one, within the range that was stated.
By their numbers in this assay, from the lowest: compounds 3, 1, 2 and 4 (each within the scatter of the next).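

In this assay, ethyl in place of hydrogen on a saturated chain carbon, five bonds along the chain from an oxygen on a saturated carbon, gives a 1.2-fold higher number from compound 2 to compound 4 (0.08 log units; within the scatter). The earlier compounds showed this change only at a site three bonds along the chain, so compound 4 extends the flat picture to a second site and to the longest chain shown here. Read on the two cores, the change gives steps that agree: the same change on two cores in this assay, a 1.0-fold lower number (0.01 log units; within the scatter) from compound 1 to compound 3 and a 1.2-fold higher number (0.08 log units; within the scatter) from compound 2 to compound 4, 1.2-fold (0.09 log units) apart, within the scatter of two such steps

As far as these compounds go, whether a longer chain than that of compound 4, or an amine or a carboxylic acid in place of the chain, would move the number beyond the scatter remains open. Also open, from the compounds shown here alone, is how the chain of compound 4 behaves with methoxy on the aromatic carbon.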